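Swapping cyano for isopropyl on the shared core

The source may report more compounds than this note shows. Statements on the series, on what has been measured and on what is new or still open speak of the compounds shown alone.

In an ADME assay on microsomes from liver (Homo sapiens) for metabolic stability, read by LC-MS, using NADPH, tested at 1 uM (on this read-out higher numbers stand for fast clearance and lower numbers for slow clearance), compound 1 `N#Cc1cnc(NC(=O)CCCOc2ccccc2)s1` gives 198 mL.min-1.g-1 and stands within the scatter of both other measured compounds. Compound 2 `Cc1cnc(NC(=O)CCCOc2cccc(C#N)c2)s1` gives 172 mL.min-1.g-1 and compound 3 `Cc1cnc(NC(=O)CCCOc2cccc(Cl)n2)s1` gives 250 mL.min-1.g-1 on the same read-out, so these numbers set no order among the three. For the measured compounds named here, no two measured compounds differ in one place only, which leaves the size of any single change in this assay unmeasured.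

Compound 4 `CC(C)c1cnc(NC(=O)CCCOc2ccccc2)s1` is not yet measured and differs from compound 1 by one change isopropyl in place of cyano on an aromatic carbon on the shared core: isopropyl in place of cyano on an aromatic carbon, next to the ring sulfur. Going by the values given here, the only guide is indirect. Compound 2 and compound 3 both lack the cyano on that carbon, and compound 3 still gives 250 mL.min-1.g-1 although it also differs from compound 1 elsewhere. Losing the cyano is therefore not expected to move the number far. The expected step is a 1.3-fold higher number from compound 1 to compound 4 (0.12 log units; within the scatter) towards faster clearance, small enough to stay within the scatter. The estimate for compound 4 is 260 mL.min-1.g-1 with a range from 130 mL.min-1.g-1 to 500 mL.min-1.g-1 expected.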

Compound 4, intrinsic clearance in microsomes: 232 mL.min-1.g-1
Estimate against measurement, compound 4: 1.1-fold (0.05 log units) above; the measured number falls inside the stated range.
By their numbers in this assay, from the lowest: compounds 2, 1, 4 and 3 (each within the scatter of the next).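

In this assay, for the compounds shown here, the one step that can be read at this position, isopropyl in place of cyano on an aromatic carbon next to the ring sulfur, is a 1.2-fold higher number from compound 1 to compound 4 (0.07 log units; within the scatter) and so gives the first direct reading of a single change on the shared core. Cyano, with its triple bond and hydrogen-bond acceptor, and isopropyl, with three carbons and no hydrogen-bond acceptor, are not separated by this read-out when the rest of compound 1 is held fixed, so this exchange leaves the number inside the usual scatter. Nothing measured on these compounds accounts for this result or says what either group does here.

Going by these compounds, whether an amine, a carboxylic acid or a longer alkyl chain at this position would read apart from cyano and isopropyl stays open, and a single step sets no trend for the position. Compound 2 and compound 3 each differ from compound 1 and compound 4 in more than one place, so the steps involving them cannot be read, and the effect of changes elsewhere on the shared core remains unresolved.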